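The compounds below may be only part of what the source reports. "The series", "measured", "known", "first", "only" and "open" are said of these compounds alone.

Compound 1 `COC(=O)C(=O)CNC1=CS(=O)(=O)O[C@@]12[C@@H](CO[Si](C)(C)C(C)(C)C)O[C@@H](n1cc(C)c(=O)n(C)c1=O)[C@@H]2O[Si](C)(C)C(C)(C)C` is the starting point. In a functional assay on MT4 cells (Homo sapiens) (on this read-out higher numbers stand for lower toxicity in this test and lower numbers for higher toxicity in this test), compound 1 gives 10300 nM, the lowest of the three numbers shown, though its gaps to the other two are within the scatter. Compound 2 `COC(=O)CC(=O)NC1=CS(=O)(=O)O[C@@]12[C@@H](CO[Si](C)(C)C(C)(C)C)O[C@@H](n1cc(C)c(=O)n(C)c1=O)[C@@H]2O[Si](C)(C)C(C)(C)C` gives 11900 nM in this assay, and compound 3 `Cc1cn([C@@H]2O[C@H](CO[Si](C)(C)C(C)(C)C)[C@@]3(OS(=O)(=O)C=C3NCCC(=O)O)[C@H]2O[Si](C)(C)C(C)(C)C)c(=O)n(C)c1=O` gives 11500 nM. The measured steps are all flat: a 1.2-fold higher number from compound 1 to compound 2 (0.06 log units; within the scatter), a 1.1-fold higher number from compound 1 to compound 3 (0.05 log units; within the scatter) and a 1.0-fold lower number from compound 2 to compound 3 (0.01 log units; within the scatter). Compound 4 `Cc1cn([C@@H]2O[C@H](CO[Si](C)(C)C(C)(C)C)[C@@]3(OS(=O)(=O)C=C3NCC(=O)C(=O)N3CCC3)[C@H]2O[Si](C)(C)C(C)(C)C)c(=O)n(C)c1=O` differs from compound 1 by azetidin-1-yl in place of methoxy on a carbonyl carbon. Going by the values given here, no measured step exchanges a group at that carbonyl carbon; the three measured steps instead replace the whole chain on the amine nitrogen, and even those larger exchanges leave this assay unchanged beyond the scatter. The smaller exchange here, on the shared core with both silyl groups kept, is therefore expected to give no step beyond the scatter, so that compound 4 is estimated at 10500 nM, between 5500 nM and 20000 nM, an expected step of a 1.0-fold higher number from compound 1 to compound 4 (0.01 log units; within the scatter).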

Compound 4, half-maximal cytotoxic concentration: 17400 nM
The estimate for compound 4 lay 1.7-fold (0.22 log units) below the measured number, and the stated range covers the measured number.
By their numbers in this assay, from the lowest: compounds 1, 3, 2 and 4 (each within the scatter of the next).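

Going by these compounds alone, at this carbonyl carbon, azetidin-1-yl in place of methoxy gives in this assay the first reading for an exchange at this place, with a 1.7-fold higher number from compound 1 to compound 4 (0.23 log units; within the scatter) on the shared core, so a group carrying a four-membered ring is accommodated here without a step beyond the scatter. The exchanges of the whole chain that bring in this group stay within the scatter as well, with a 1.5-fold higher number from compound 3 to compound 4 (0.18 log units; within the scatter) and with a 1.5-fold higher number from compound 2 to compound 4 (0.17 log units; within the scatter) in the same read-out. Nothing available explains these readings.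

The compounds shown leave open whether a carboxylic acid, a dimethylamino group or the larger piperidin-1-yl ring at this carbonyl carbon would also stay within the scatter. Going by these compounds, all four compounds carry both silyl groups, so whether this exchange reads the same on a core with free hydroxyl groups remains open.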